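This account rests on a few compounds, and the source may have more. Where it says the series, first, only, none or still open, it means among the compounds named here.

Working notes on the series

Two compounds have numbers in an assay on cell membranes for displacement of a labelled ligand from Neuronal acetylcholine receptor; alpha4/beta2 (Rattus norvegicus); a higher number here means a weaker inhibitor, a lower number a stronger inhibitor. Compound 1 `Clc1ccc(Nc2ccc(N3CC4CC(C3)N4)nn2)cc1Cl` gives 516 nM in this assay. Compound 2 `COc1ccc(Nc2cncc(N3CC4CC(C3)N4)c2)cc1` gives 0.0598 nM in this assay, the lower of the two numbers and far from that of compound 1, a gap well beyond the scatter. The two differ in more than one place, so the gap cannot be tied to any single change; it only shows where compound 2 stands, at the stronger end of what has been measured.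

Compound 3 `Cc1ccc(Nc2cncc(N3CC4CC(C3)N4)c2)cc1` is the next compound and has not yet been measured. Compared with compound 2 the change is methyl in place of methoxy on an aromatic carbon. Among the compounds with values here, no measured pair shows this exchange, so there is no step on record to draw on. The expectation is a small step, no larger than the scatter or at most a modest loss, with compound 3 estimated to sit slightly higher than compound 2, a step from compound 2 to compound 3 of a 2.0-fold higher number from compound 2 to compound 3 (0.30 log units; within the scatter) in this assay. Compound 3 is expected to give 0.12 nM in this assay, within a range of 0.02 nM to 0.7 nM.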

Compound 3, inhibition constant: 0.148 nM
Estimate against measurement, compound 3: 1.2-fold (0.09 log units) below; low and high end bracket the measured number.
By their numbers in this assay, from the lowest: compound 2; then compound 3; then compound 1.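

In this assay, within the data shown here, the exchange of methoxy for methyl, on an aromatic carbon para to a large group, gives a 2.5-fold higher number from compound 2 to compound 3 (0.39 log units; beyond the scatter) and is the first single change on record. The step is modest yet beyond the scatter, so this position does register the exchange, although compound 3, with one heavy atom and no hydrogen-bond acceptor in the entering group, stays close to compound 2 on the scale of this assay. No measurement on hand explains the direction or the size of this step.

The compounds shown leave open how a bare hydrogen, a chlorine atom, an amine, a carboxylic acid or a longer chain such as ethoxy would read at this same carbon, and therefore whether methoxy is unusual here or simply one of many groups that give similar numbers. Also open, from the compounds shown here alone, is whether the exchange of methoxy for methyl gives a step of similar size on a different core, such as the core of compound 1.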